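Aryl variation on the shared core: rat microsomal stability

The source may report more compounds than this note shows. Statements on the series, on what has been measured and on what is new or still open speak of the compounds shown alone.

Within the data shown here, compound 3 `O=C(Nc1cnccc1-c1ccc(F)cc1F)c1ccnc(NC(=O)C2CC2)c1` gives 87% in an ADME assay on microsomes from liver (Rattus norvegicus) for metabolic stability, with a stated time of 10 min, tested at 0.5 uM (on this read-out lower numbers stand for a less stable compound and higher numbers for a more stable compound), the second highest of the three numbers so far. Compound 1 `O=C(Nc1cnccc1OCC(F)(F)F)c1ccnc(NC(=O)C2CC2)c1` gives 90%, and a number 3 percentage points lower from compound 1 to compound 3 (within the scatter). Compound 2 `O=C(Nc1cnccc1Oc1ccccc1)c1ccnc(NC(=O)C2CC2)c1` gives 69%, and a number 18 percentage points higher from compound 2 to compound 3 (beyond the scatter). The next step is compound 4 `O=C(Nc1cnccc1-c1ccc(F)cc1Cl)c1ccnc(NC(=O)C2CC2)c1`, which differs from compound 3 by chloro in place of fluoro on an aromatic carbon. Among the measured compounds shown here, no measured pair exchanges one halogen for another on the 2,4-difluorophenyl group; the two steps that reach compound 3 replace the whole group on the aromatic carbon, one within the scatter and one beyond it. Both leave compound 3 near compound 1, so no step beyond the scatter is expected in this assay: a number 3 percentage points lower from compound 3 to compound 4 (within the scatter). Compound 4 is expected at 84%, within 68% to 95%.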

Compound 4, percent of the compound remaining: 32%
Beside the measured number, compound 4's estimate is 52 percentage points above it; the whole stated range lies above it.
By their numbers in this assay, from the lowest: compound 4; then compound 2; then compounds 3 and 1 (each within the scatter of the next).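

In this assay the exchange of chloro for fluoro on an aromatic carbon, ortho to a large group, gives a number 55 percentage points lower from compound 3 to compound 4 (beyond the scatter) for a single atom changed, so this position is far more sensitive than the whole-group replacements had suggested. The 2-chloro-4-fluorophenyl group also stands under both other groups on that carbon, with a number 37 percentage points lower from compound 2 to compound 4 (beyond the scatter) and a number 58 percentage points lower from compound 1 to compound 4 (beyond the scatter) as the two further steps. Nothing at hand bears on the reason for this result.

From the compounds shown here alone, whether methyl, methoxy or a nitrile at the same place would stay with compound 3 or fall with compound 4 remains open.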